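The compounds below may be only part of what the source reports. "The series", "measured", "known", "first", "only" and "open" are said of these compounds alone.

In a functional assay on HeLa cells (Homo sapiens) for inhibition, read by sulforhodamine B assay (on this read-out lower numbers stand for stronger inhibition and higher numbers for weaker inhibition), compound 1 `CCCc1ccc(NC2=CC(=O)c3nc4n(c3C2=O)[C@H]2OC[C@@H](O)[C@H]2OC4)cc1` gives 4990 nM and compound 2 `O=C1C(Nc2ccccc2F)=CC(=O)c2c1nc1n2[C@H]2OC[C@@H](O)[C@H]2OC1` gives 9820 nM, so the two lie within the usual scatter of each other. Compound 3 `O=C1C(Nc2ccccc2)=CC(=O)c2c1nc1n2[C@H]2OC[C@@H](O)[C@H]2OC1` gives > 8000 nM, which is a limit of the assay and not a number.

The next compound to consider is compound 4 `O=C1C=C(Nc2ccccc2F)C(=O)c2c1nc1n2[C@H]2OC[C@@H](O)[C@H]2OC1`, which keeps the core of compound 1 and swaps one group: 2-fluorophenyl in place of 4-propylphenyl on an amine nitrogen. In words, 2-fluorophenyl takes the place of 4-propylphenyl on an amine nitrogen.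

Among the compounds with values here, no measured step makes this exact change. Within the data shown here, the only step on record is a step that the limit leaves unreadable from compound 2 to compound 3, so it gives no size to carry over. The closest guide is compound 2, which also carries 2-fluorophenyl and gives 9820 nM, although its structure is not identical to that of compound 4.

With nothing pointing to a large shift in this assay, the expected change is a 1.3-fold higher number from compound 1 to compound 4 (0.11 log units; within the scatter), with no step beyond the scatter anticipated in either direction. For compound 4 the estimated value is 6500 nM, with an expected range from 2500 nM to 17000 nM.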

Compound 4, half-maximal inhibitory concentration: 5120 nM
Compound 4: middle estimate off by 1.3-fold (0.10 log units), on the high side, and the stated range covers the measured number.
By their numbers in this assay, from the lowest: compounds 1, 4 and 2 (each within the scatter of the next).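

In this assay the change on the amine nitrogen gives a 1.0-fold higher number from compound 1 to compound 4 (0.01 log units; within the scatter). Within the data shown here, this is the only readable step here, and it shows that 2-fluorophenyl can take the place of 4-propylphenyl on the core of compound 1 without a shift beyond the scatter, even though the two groups differ in size and in the atoms they carry. The earlier step between compound 2 and compound 3 cannot be read, because it ends in a limit of the assay and not a number: the limit of > 8000 nM in this assay, at which 1 of the 4 values shown sits.

Both the propyl chain and the fluorine change in this single step, so the part played by each cannot be separated. From the compounds shown here alone, whether an amine, a carboxylic acid or a longer chain in place of these groups would also leave the number within the scatter remains open.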